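Fluoro on the phenyl group: a second matched pair

A few compounds are considered here, and "the series" means these few. Any claim that something is new, unique, unknown or untested is made for them only; others in the source may bear on it.

Compound 1 `C=C1C[C@]23C[C@@]1(O)CC[C@H]2c1cc(Br)c(O)c(C)c1[C@@H]3Cn1cc(-c2ccccc2)nn1` and compound 2 `C=C1C[C@]23C[C@@]1(O)CC[C@H]2c1cc(Br)c(O)c(C)c1[C@@H]3Cn1cc(-c2ccc(F)cc2)nn1` form the first pair; compound 2 carries fluoro in place of hydrogen on an aromatic carbon. In a functional assay on SMMC-7721 cells (Homo sapiens) for cytotoxicity, read by MTT assay, with a stated time of 4 days (a higher number here means a weaker inhibitor, a lower number a stronger inhibitor), compound 1 gives > 20000 nM, which is a limit of the assay rather than a number. Compound 2 likewise gives > 20000 nM, again a limit. The step that the two limits leave unreadable from compound 1 to compound 2 therefore cannot be read, because of the limit of > 20000 nM in this assay, at which 3 of the 3 values shown sit.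

Compound 3 `C=C1C[C@]23C[C@@]1(O)CC[C@@H]2c1cccc(C)c1[C@@H]3Cn1cc(-c2ccccc2)nn1` rests on a different core; the difference between the two cores is not broken down here. In this assay compound 3 gives > 20000 nM, a limit. Compound 4 `C=C1C[C@]23C[C@@]1(O)CC[C@@H]2c1cccc(C)c1[C@@H]3Cn1cc(-c2ccc(F)cc2)nn1` is its unmeasured partner, carrying (fluoro in place of hydrogen on an aromatic carbon); the place is the same in both pairs, so this is the same change.

Expectation: the measured pair gives no readable size for this change, and every value shown sits at the limit. For compound 4 the step that the limit leaves unreadable from compound 3 to compound 4 is expected to be small or again unreadable. Compound 4 is estimated at 30000 nM, with a range from 15000 nM to 80000 nM, most likely reported once more as a limit.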

Compound 4, half-maximal inhibitory concentration: > 20000 nM
Compound 4: no number, only a limit; the forecaster's own chance of this, stated with the estimate: 85%; the middle value does not contradict the limit.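

In this assay compound 4 gives > 20000 nM, a limit and not a number. No size can be read for the change from phenyl to 4-fluorophenyl between compound 3 and compound 4, because the values give no number to compare: the limit of > 20000 nM in this assay, at which 4 of the 4 values shown sit.

The compounds shown leave open whether the fluoro group or the difference between the two cores alters potency in this assay.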